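Pyrrolidinyl Returns with an Acetamido Substituent

The compounds below may be only part of what the source reports. "The series", "measured", "known", "first", "only" and "open" are said of these compounds alone.

Going by the values given here, compound 2 `CN(C)c1ccc2cc(NC(=O)CCc3ccc(C(F)(F)F)cc3)ccc2n1` gives 13 nM in an assay on isolated protein for displacement of a labelled ligand from melanin-concentrating hormone receptor 1 (Homo sapiens) (a higher number here means a weaker inhibitor, a lower number a stronger inhibitor), the highest of the two numbers measured so far, while compound 1 `CC1CCN(c2ccc3cc(NC(=O)CCc4ccc(C(F)(F)F)cc4)ccc3n2)C1` gives 2 nM. Among the compounds with values here, the single measured step, a 6.5-fold higher number from compound 1 to compound 2 (0.81 log units; beyond the scatter), shows 3-methylpyrrolidin-1-yl ahead of dimethylamino. From the compounds shown here alone, compound 3 `CC(=O)NC1CCN(c2ccc3cc(NC(=O)CCc4ccc(C(F)(F)F)cc4)ccc3n2)C1` differs from compound 2 by 3-acetamidopyrrolidin-1-yl in place of dimethylamino on an aromatic carbon, bringing back a five-membered ring, now carrying an acetamido group whose effect is untested. Since that step was modest and bears directly on this change, compound 3 is expected to show a lower number, about a 2.6-fold lower number from compound 2 to compound 3 (0.41 log units; beyond the scatter). The value of compound 3 in this assay is estimated at 5 nM, ranging from 1.5 nM to 20 nM.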

Compound 3, half-maximal inhibitory concentration: 5 nM
Compound 3: the middle estimate sits on the measured number at the digits printed; the measured number falls inside the stated range.
By their numbers in this assay, from the lowest: compound 1; then compound 3; then compound 2.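

In this assay the position on the aromatic carbon next to the ring nitrogen accepts the bigger 3-acetamidopyrrolidin-1-yl, which gives a 2.6-fold lower number from compound 2 to compound 3 (0.41 log units; beyond the scatter) and so keeps an advantage over dimethylamino even with an acetamido group on the ring. The substituent on the saturated ring also matters, since acetamido in place of methyl gives a 2.5-fold higher number from compound 1 to compound 3 (0.40 log units; beyond the scatter) and is the first change shown at that ring carbon. No measurement given here accounts for either step. The compounds shown leave open how the unsubstituted pyrrolidin-1-yl ring would compare, and how a free amine or a hydroxyl group on that ring carbon would fare.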